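The source may report more compounds than this note shows. Statements on the series, on what has been measured and on what is new or still open speak of the compounds shown alone.

Of the compounds shown here, three built on one shared core have been tested in a functional assay on the whole organism (strain albino) with Mus musculus as the target, in the maximal electroshock model, with a stated time of 0.5 h; on this read-out higher numbers stand for an effect only at larger amounts of compound and lower numbers for an effect already at smaller amounts. Compound 1, with the structure `Cc1ccccc1Nc1nnc(Nc2nc(-c3ccc(Br)cc3)cs2)s1`, gives 300 mg/kg in this assay. Compound 2, `Cc1ccc(Nc2nnc(Nc3nc(-c4ccc(Br)cc4)cs3)s2)cc1`, gives 100 mg/kg. Compound 3, `Cc1ccccc1Nc1nnc(Nc2nc(-c3ccccc3)cs2)s1`, gives 300 mg/kg.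

Two single changes connect these numbers. The change from compound 1 to compound 2 is 4-methylphenyl in place of 2-methylphenyl on a nitrogen on an aromatic ring, and it produced a 3.0-fold lower number from compound 1 to compound 2 (0.48 log units; beyond the scatter). The change from compound 1 to compound 3 is hydrogen in place of bromo on an aromatic carbon, and it produced no change at the digits printed from compound 1 to compound 3 (within the scatter), so compound 1 and compound 3 stand level at the digits printed and together hold the highest numbers of the three.

Compound 4, `Cc1ccc(Nc2nnc(Nc3nc(-c4ccccc4)cs3)s2)cc1`, has not yet been measured in this assay. It differs from compound 3 by 4-methylphenyl in place of 2-methylphenyl on a nitrogen on an aromatic ring, the same change already seen between compound 1 and compound 2, made here on a core that differs from the core of compound 1 by hydrogen in place of bromo on an aromatic carbon. Since the earlier instance of this change moved the number by a 3.0-fold lower number from compound 1 to compound 2 (0.48 log units; beyond the scatter), and since compound 3 starts from 300 mg/kg, level with compound 1, the expectation is that compound 4 will show a step of about a 3.0-fold lower number from compound 3 to compound 4 (0.48 log units; beyond the scatter) in this assay. On that basis compound 4 is estimated at 100 mg/kg, with a range from 30 mg/kg to 300 mg/kg considered plausible given that the precedent rests on a single pair.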

Compound 4, minimum effective dose: 100 mg/kg
Compound 4: the middle estimate sits on the measured number at the digits printed; the measured number falls inside the stated range.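

In this assay, 4-methylphenyl in place of 2-methylphenyl on a nitrogen on an aromatic ring gives a 3.0-fold lower number from compound 3 to compound 4 (0.48 log units; beyond the scatter) on the core that carries hydrogen instead of bromo, and this step matches its earlier counterpart on the bromo core: the same change on two cores in this assay, a 3.0-fold lower number (0.48 log units; beyond the scatter) from compound 1 to compound 2 and a 3.0-fold lower number (0.48 log units; beyond the scatter) from compound 3 to compound 4, 1.0-fold (0.00 log units) apart, within the scatter of two such steps. The second change also carries over, as hydrogen in place of bromo on an aromatic carbon gives no change at the digits printed from compound 2 to compound 4 (within the scatter) with the 4-methylphenyl group present, just as it did with the 2-methylphenyl group: the same change on two cores in this assay, no change at the digits printed (within the scatter) from compound 1 to compound 3 and no change at the digits printed (within the scatter) from compound 2 to compound 4, 1.0-fold (0.00 log units) apart, within the scatter of two such steps. Across these four compounds, then, the effect of swapping 2-methylphenyl for 4-methylphenyl holds on both cores and the bromo group makes no difference to it, but this rests on only two pairs in a single assay, shows nothing about cores further removed from these, and gives no reason for the step.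

The compounds shown vary the outer aromatic ring only between bromo and hydrogen, so they leave open whether a methoxy group, an amine or a carboxylic acid at that place would also leave the number unchanged. They also leave open how an ethyl chain in place of the methyl, or a plain phenyl group on the nitrogen, would compare with the two methylphenyl groups.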